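A few compounds are considered here, and "the series" means these few. Any claim that something is new, unique, unknown or untested is made for them only; others in the source may bear on it.

Compound 1 `c1ccc(C(c2cccnc2)N2CCN(c3ncnc4c3cnn4-c3ccccc3)CC2)cc1`: > 25000 nM
Compound 2 `c1ccc(C(c2ccco2)N2CCN(c3ncnc4c3cnn4-c3ccccc3)CC2)cc1`: > 25000 nM
Compound 3 `Cc1ccccc1C(c1sccc1C)N1CCN(c2ncnc3c2cnn3-c2ccccc2)CC1`: > 25000 nM

In a functional assay on cells (Rhabdomyosarcoma cell, Homo sapiens) for cytotoxicity (a higher number here means a weaker inhibitor, a lower number a stronger inhibitor), compound 1 gives only a limit, > 25000 nM, and no number. Compound 2 likewise gives only a limit in this assay, > 25000 nM. Compound 3 too stands at a limit in this assay, > 25000 nM. All three values shown thus sit at the same point, (the limit of > 25000 nM in this assay, at which 3 of the 3 values shown sit), and none of the compounds can be ordered against the others. For the measured compounds named here, the single step among them, a step that the two limits leave unreadable from compound 1 to compound 2, has no readable size, both of its ends being limits.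

Compound 4 `c1ccc(C(c2ccncc2)N2CCN(c3ncnc4c3cnn4-c3ccccc3)CC2)cc1` is not yet measured in this assay. It differs from compound 1 in one place: pyridin-4-yl in place of pyridin-3-yl on a saturated chain carbon bound to an amine nitrogen in a ring and an aromatic carbon. Going by the values given here, the only measured step that bears on a change at that carbon, a step that the two limits leave unreadable from compound 1 to compound 2, gave no readable size, and compound 3 with its different groups also stands at the limit. Nothing in the measured set points to a pyridyl exchange moving compound 4 away from where compound 1 stands. The expected step that the limit leaves unreadable from compound 1 to compound 4 is therefore none beyond the scatter. The estimate for compound 4 in this assay is 40000 nM, with an expected range from 15000 nM to 100000 nM, and compound 4 is expected most likely to be reported only as a limit.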

Compound 4, half-maximal inhibitory concentration: > 25000 nM
Compound 4: a limit, no number (the forecaster's own chance of this, stated with the estimate: 90%); the middle value lies beyond the limit too.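

Compound 4 also gives only a limit in this assay, > 25000 nM, so its steps against compound 1 and compound 2 cannot be read, and no new step emerges: the limit of > 25000 nM in this assay, at which 4 of the 4 values shown sit.

The compounds shown leave open whether any change at the saturated chain carbon can bring a measurable value in this assay.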